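Sulfonamide series: from compound 1 to compound 3

The source may report more compounds than this note shows. Statements on the series, on what has been measured and on what is new or still open speak of the compounds shown alone.

Going by the values given here, compound 1 `O=S(=O)(NCCCCNCc1ccc(Br)cc1)c1cc(C(F)(F)F)cc(C(F)(F)F)c1` stands alongside the only other measured member: in a functional assay on HPAC cells (Homo sapiens) for inhibition, read by MTT assay, with a stated time of 72 h (on this read-out higher numbers stand for weaker inhibition of growth and lower numbers for stronger inhibition of growth), compound 1 gives 2000 nM. Compound 2 `O=S(=O)(NCCCNCc1ccc(Cl)c(C(F)(F)F)c1)c1cc(C(F)(F)F)cc(C(F)(F)F)c1` in this assay gives 3000 nM, and the two numbers lie within the usual scatter of each other. Compound 3 `CN(CCCNS(=O)(=O)c1cc(C(F)(F)F)cc(C(F)(F)F)c1)Cc1ccccc1` carries benzyl(methyl)amino in place of ((4-bromobenzyl)amino)methyl on a saturated chain carbon, three bonds along the chain from a sulfonamide nitrogen. Among the compounds with values here, no pair of measured compounds covers this change, so no step size is known for it. The step of a 2.0-fold higher number from compound 1 to compound 3 (0.30 log units; within the scatter) is expected to be a modest move toward weaker growth inhibition, close to the edge of the scatter. Compound 3 is estimated at 4000 nM, with a range of 1500 nM to 12000 nM.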

Compound 3, concentration for 50% growth inhibition: 30000 nM
The estimate for compound 3 lay 7.5-fold (0.88 log units) below the measured number; the measured number lies above the stated range.
By their numbers in this assay, from the lowest: compounds 1 and 2 (each within the scatter of the next); then compound 3.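

In this assay, benzyl(methyl)amino in place of ((4-bromobenzyl)amino)methyl gives a 15-fold higher number from compound 1 to compound 3 (1.18 log units; beyond the scatter) and so shows that this place on the chain is sensitive to change, a large step beyond the scatter. The swap is composite: bromine leaves, and the entering group has 0 hydrogen-bond donors against 1 in the leaving group. Nothing at hand bears on the cause of the step.

As far as these compounds go, how much of the step follows the bromine and how much the nitrogen substitution stays open. A 4-bromobenzyl group on a methylated nitrogen would help separate the two.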